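A Methyl Gives Way to Hydrogen on the Core

This account rests on a few compounds, and the source may have more. Where it says the series, first, only, none or still open, it means among the compounds named here.

Compound 2 `Cc1nc2c(Br)c(Br)c(Br)c(Br)c2n1CCCC#N` and compound 1 `Cc1nc2c(Br)c(Br)c(Br)c(Br)c2n1CC#N` share one core. In a functional assay on MCF7 cells (Homo sapiens) for cytotoxicity, read by MTT assay, with a stated time of 24 h, tested at 50 uM (on this read-out higher numbers stand for a weaker effect at the one concentration tested and lower numbers for a stronger effect), compound 1 gives 11%, while compound 2 gives 5%; the step of a number 6 percentage points lower from compound 1 to compound 2 (within the scatter) lies within the scatter, so compound 2 stands alongside compound 1 rather than apart from it. Compound 3 `N#CCCCn1cnc2c(Br)c(Br)c(Br)c(Br)c21` differs from compound 2 by hydrogen in place of methyl on an aromatic carbon. For the measured compounds named here, no measured step touches this aromatic carbon, so nothing seen so far bears on the change, and no step beyond the scatter is expected in this assay. Compound 3 is therefore estimated at 7%, between 0% and 20%, a step of a number 2 percentage points higher from compound 2 to compound 3 (within the scatter).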

Compound 3, a percentage reported as activity, at one concentration (the size of the read-out at that concentration, not a potency): 16%
Beside the measured number, compound 3's estimate is 9 percentage points below it; the measured number falls inside the stated range.
By their numbers in this assay, from the lowest: compounds 2, 1 and 3 (each within the scatter of the next, the first and the last beyond it).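

In this assay the methyl on this aromatic carbon, between two ring nitrogen atoms, proves to matter: replacing it with hydrogen gives a number 11 percentage points higher from compound 2 to compound 3 (beyond the scatter) and so a modestly weaker effect. Unlike the chain change, a number 6 percentage points lower from compound 1 to compound 2 (within the scatter) which stays within the scatter, this change gives a step that the read-out can separate from it. No measurement at hand gives a reason for this shift. Still open, going by these compounds, is whether an amine or an ethyl group on this carbon would move the number, and whether the methyl matters equally with the shorter chain of compound 1.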